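This account rests on a few compounds, and the source may have more. Where it says the series, first, only, none or still open, it means among the compounds named here.

Measured compounds in a functional assay on ileum for inhibition of histamine H1 receptor (Cavia porcellus); on this read-out higher numbers stand for weaker inhibition and lower numbers for stronger inhibition:
compound 1 `CCOCCn1c(N2CCN(C)CC2)nc2ccccc21` gives 10 nM
compound 2 `CCOCCn1c(N2CCNCC2)nc2ccccc21` gives 11 nM
compound 3 `CCCCCN1CCN(c2nc3ccccc3n2CCOCC)CC1` gives 30 nM

Compound 1 has the lowest number of the three. The step of a 1.1-fold higher number from compound 1 to compound 2 (0.04 log units; within the scatter) stays within the scatter, so compounds 1 and 2 cannot be told apart on this read-out. The steps of a 3.0-fold higher number from compound 1 to compound 3 (0.48 log units; beyond the scatter) and a 2.7-fold higher number from compound 2 to compound 3 (0.44 log units; beyond the scatter) go beyond the scatter and are modest in size.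

Compound 4 `CCCSCn1c(N2CCN(C)CC2)nc2ccccc21` differs from compound 1 by propylsulfanyl in place of ethoxymethyl on a saturated chain carbon bound to an aromatic nitrogen. All three measured steps concern the amine nitrogen in the ring and what sits on it; none of them touches the saturated chain carbon bound to the aromatic nitrogen. Going by the values given here, no measured step therefore bears on the change from compound 1 to compound 4, and its direction cannot be read from the series. Among the compounds with values here, the three numbers so far span less than one order, which argues for an expectation close to compound 1 with a wide range. The expected step is a 2.0-fold higher number from compound 1 to compound 4 (0.30 log units; within the scatter). For compound 4 the estimate in this assay is 20 nM, with a range from 5 nM to 80 nM.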

Compound 4, half-maximal inhibitory concentration: 68 nM
Compound 4: middle estimate off by 3.4-fold (0.53 log units), on the low side, within the range that was stated.
By their numbers in this assay, from the lowest: compounds 1 and 2 (each within the scatter of the next); then compound 3; then compound 4.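

Going by these compounds alone, replacing ethoxymethyl with propylsulfanyl on a saturated chain carbon bound to an aromatic nitrogen gives a 6.8-fold higher number from compound 1 to compound 4 (0.83 log units; beyond the scatter) in this assay and so shows that this place, untouched by the earlier steps, is not indifferent to the change. The step occurs with the heavy-atom and hydrogen-bond counts unchanged, and it is larger than a 3.0-fold higher number from compound 1 to compound 3 (0.48 log units; beyond the scatter) on the amine side of the series. Nothing available explains the step.

Read one bond further out, the same difference is 2-ethoxyethyl to (propylsulfanyl)methyl, so this single pair cannot separate the exchange of oxygen for sulfur from the altered chain arrangement. As far as these compounds go, how a 2-(ethylsulfanyl)ethyl or a benzyl group would read at this place, and whether any group here could match compound 1, remains open.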